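A Fluorine Added to a Weakly Active Core

A few compounds are considered here, and "the series" means these few. Any claim that something is new, unique, unknown or untested is made for them only; others in the source may bear on it.

Compound 1 `C(=N/c1ccccc1)\c1cc(-c2ccccc2)no1` is tested in a functional assay on COLO 205 cells (Homo sapiens) for inhibition, read by MTT assay, with a stated time of 24 h (a lower number here means a stronger inhibitor, a higher number a weaker inhibitor), where compound 1 gives 89100 nM. Compound 2 `Fc1ccc(-c2cc(/C=N/c3ccccc3)on2)cc1` differs from compound 1 by one change, (fluoro in place of hydrogen on an aromatic carbon), and in this assay compound 2 gives 33100 nM. That change produced a 2.7-fold lower number from compound 1 to compound 2 (0.43 log units; beyond the scatter).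

Compound 3 `CCc1cc2ccccc2nc1-c1cc(-c2ccccc2)no1` is built on another core; the difference between the two cores is not broken down here. In this assay compound 3 reaches only a limit of the assay, > 100000 nM, so no number is known for it. This is the limit described by the limit of > 100000 nM in this assay, at which 1 of the 3 values shown sits.

Compound 4 `CCc1cc2ccccc2nc1-c1cc(-c2ccc(F)cc2)no1` has not yet been measured. It differs from compound 3 by fluoro in place of hydrogen on an aromatic carbon, the same change that separates compound 1 from compound 2, made at the same kind of place. Compound 3 gave only a limit, and the step from it to compound 4 therefore cannot be read off directly. The expectation rests instead on the earlier step, a 2.7-fold lower number from compound 1 to compound 2 (0.43 log units; beyond the scatter), applied to compound 3. In this assay the same change made on compound 3 is expected to give an at least 1.4-fold lower number from compound 3 to compound 4 (0.15 log units; that floor lies within the scatter). Compound 4 is thus estimated at 70000 nM, with a plausible range from 30000 nM to 200000 nM, and with a real chance that compound 4 again returns only a limit rather than a number.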

Compound 4, half-maximal inhibitory concentration: > 100000 nM
Compound 4 gave a limit, no number (the forecaster's own chance of this, stated with the estimate: 55%); middle value at least 1.4-fold (0.15 log units) away from the limit.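

In this assay compound 4 gives > 100000 nM as a limit of the assay, not a number. Among these compounds, compound 3 gave a limit too, so no step between compound 3 and compound 4 can be read: the limit of > 100000 nM in this assay, at which 2 of the 4 values shown sit. The compounds shown leave open whether fluoro in place of hydrogen changes the result on the core of compound 3 at all.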